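The source may report more compounds than this note shows. Statements on the series, on what has been measured and on what is new or still open speak of the compounds shown alone.

Measured in a functional assay on WM 266-4 cells (Homo sapiens) for antiproliferative activity, read by MTT assay, with a stated time of 24 h; on this read-out higher numbers stand for weaker inhibition of growth and lower numbers for stronger inhibition of growth:

- compound 1 `COc1ccc(C2=NN(C(=O)c3cncc(Br)c3)C(c3ccc(OC)cc3)C2)cc1`: 7560 nM
- compound 2 `COc1ccc(C2=NN(C(=O)c3ccc(Cl)nc3)C(c3ccc(OC)cc3)C2)cc1`: 6450 nM
- compound 3 `COc1ccc(C2=NN(C(=O)c3ccc(C)nc3)C(c3ccc(OC)cc3)C2)cc1`: 4930 nM

Compound 3 cannot be separated from the other two compounds on these numbers. The data show a 1.5-fold lower number from compound 1 to compound 3 (0.19 log units; within the scatter) and a 1.3-fold lower number from compound 2 to compound 3 (0.12 log units; within the scatter), so it sits in a tight group with them.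

The next compound is compound 4 `COc1ccc(C2=NN(C(=O)c3ccc(C)nc3)C(c3ccc(Br)cc3)C2)cc1`, which differs from compound 3 by one change: bromo in place of methoxy on an aromatic carbon. In words, this is bromo in place of methoxy on an aromatic carbon, or 4-methoxyphenyl to 4-bromophenyl.

Within the data shown here, no measured step touches this place. The three steps available all concern the group on the carbonyl carbon: a 1.2-fold lower number from compound 1 to compound 2 (0.07 log units; within the scatter), a 1.5-fold lower number from compound 1 to compound 3 (0.19 log units; within the scatter) and a 1.3-fold lower number from compound 2 to compound 3 (0.12 log units; within the scatter). They show that this assay barely moved across those replacements, but they say nothing direct about the new change, so the expectation remains loose. The best anchor is compound 3 at 4930 nM, and no shift beyond the scatter is expected, though one in either direction cannot be excluded.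

The expected step is a 1.1-fold lower number from compound 3 to compound 4 (0.04 log units; within the scatter).

For compound 4 the estimated value is 4500 nM, with an expected range from 1600 nM to 12000 nM.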

Compound 4, concentration for 50% growth inhibition: 4280 nM
The estimate for compound 4 lay 1.1-fold (0.02 log units) above the measured number; the measured number falls inside the stated range.
By their numbers in this assay, from the lowest: compounds 4, 3, 2 and 1 (each within the scatter of the next).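

Replacing methoxy with bromo on an aromatic carbon para to a large group is the first change shown on this side of the molecule, and in this assay it gives a 1.2-fold lower number from compound 3 to compound 4 (0.06 log units; within the scatter). Compound 3 and compound 4 therefore cannot be told apart, even though the group that leaves has 2 heavy atoms and a hydrogen-bond acceptor, while the group that enters is a single bromine with no acceptor. At this one position, then, the methoxy group and its acceptor are not needed to keep the read-out within the scatter, and the insensitivity seen so far among the groups on the carbonyl carbon now extends to this second site. No measurement shown here offers an explanation for this result.

The compounds shown leave open whether an amine, a carboxylic acid or a longer chain such as butoxy at this position would move the number beyond the scatter. They also leave open whether bromo here would give the same outcome alongside the 5-bromopyridin-3-yl or 6-chloropyridin-3-yl group on the carbonyl carbon, and what replacing the remaining methoxy group would do.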